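This account rests on a few compounds, and the source may have more. Where it says the series, first, only, none or still open, it means among the compounds named here.

The measured compounds are these.
Compound 1, `O=C(Nc1ccc(S(=O)(=O)N2CCOCC2)cc1)C1C(C(=O)O)[C@H]2CC[C@@H]1O2`, in a functional assay on A549 cells (Homo sapiens) for cytotoxicity, read by MTT assay, with a stated time of 48 h (a higher number here means a weaker inhibitor, a lower number a stronger inhibitor), gives 24200 nM.
Compound 2, `O=C(Nc1ccc(S(=O)(=O)NC2CCCC2)cc1)C1C(C(=O)O)[C@H]2CC[C@@H]1O2`, gives 20100 nM.
Compound 3, `CCOC(=O)Cc1csc(NC(=O)C2C(C(=O)O)[C@H]3CC[C@@H]2O3)n1`, gives only a limit of the assay, > 100000 nM.

Among the numbers shown, compound 2 stands next to compound 1 and is not separated from it: a 1.2-fold lower number from compound 1 to compound 2 (0.08 log units; within the scatter). Among the measured compounds shown here, the third entry, for compound 3, is a limit and not a number, so compound 2 has only one neighbour with a value, and that one lies within the scatter of it.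

Compound 4, `O=C(Nc1ccc(S(=O)(=O)NC2CCCCC2)cc1)C1C(C(=O)O)[C@H]2CC[C@@H]1O2`, is not yet measured. It differs from compound 2 in one place: cyclohexyl in place of cyclopentyl on a sulfonamide nitrogen. For the measured compounds named here, the only measured step that touches the same sulfonamide is a 1.2-fold lower number from compound 1 to compound 2 (0.08 log units; within the scatter), which exchanged one saturated ring for another on the sulfonyl sulfur and moved the number by less than the scatter. Beyond that step, the data offer only (the limit of > 100000 nM in this assay, at which 1 of the 3 values shown sits), which gives no direction. The step from compound 2 to compound 4 is therefore expected to stay within the scatter: a 1.1-fold lower number from compound 2 to compound 4 (0.05 log units; within the scatter). Compound 4 is estimated to give 18000 nM in this assay, with a likely range from 8000 nM to 45000 nM.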

Compound 4, half-maximal inhibitory concentration: 36200 nM
Estimate against measurement, compound 4: 2.0-fold (0.30 log units) below; the range from low to high includes it.
By their numbers in this assay, from the lowest: compounds 2, 1 and 4 (each within the scatter of the next). At a limit, above all of these: compound 3.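

Cyclohexyl in place of cyclopentyl on a sulfonamide nitrogen adds one ring carbon, and in this assay this change gives a 1.8-fold higher number from compound 2 to compound 4 (0.26 log units; within the scatter). Among the compounds shown here, the second new comparison, on the sulfonyl sulfur, gives a 1.5-fold higher number from compound 1 to compound 4 (0.17 log units; within the scatter), so cyclohexylamino cannot be told apart from morpholin-4-yl here, and the cyclopentylamino, cyclohexylamino and morpholin-4-yl compounds now form a set of three with no pair separated beyond the scatter. This extends the earlier single comparison to a second carbon ring on the nitrogen and to a second comparison with the morpholin-4-yl compound, but the measurements offer no cause for any of these steps.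

On these data alone, it remains open whether an open chain such as n-hexyl on the sulfonamide nitrogen, or a piperidine ring carrying a free amine in place of the carbon ring, would move the number beyond the scatter. The compounds shown also leave open what a methyl ester or a primary amide in place of the carboxylic acid on the shared core would do in this assay.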